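Replacing the Carboxy Group of Compound 1

The compounds below may be only part of what the source reports. "The series", "measured", "known", "first", "only" and "open" are said of these compounds alone.

Compound 1 `CC(C)(N)CC(=O)N[C@@H]1CCc2ccccc2N(Cc2ccc(-c3ccccc3C(=O)O)cc2)C1=O` carries a carboxy group on an aromatic carbon. For the measured compounds named here, in a functional assay (Pituitary gland cell) with Rattus norvegicus as the target (a lower number here means that less compound is needed, a higher number that more compound is needed for the effect), compound 1 gives 3 uM, the lowest of the two numbers measured so far, though the gap to its neighbour is small. Going by the values given here, compound 2 `CC(C)(N)CC(=O)N[C@@H]1CCc2ccccc2N(Cc2ccc(-c3ccccc3S(=O)(=O)NC(C)(C)C)cc2)C1=O` differs only in having a (tert-butyl)sulfamoyl group in place of that carboxy; in this assay compound 2 gives 4 uM, and the step of a 1.3-fold higher number from compound 1 to compound 2 (0.12 log units; within the scatter) is the only measured step available. Compound 3 `CC(C)(N)CC(=O)N[C@@H]1CCc2ccccc2N(Cc2ccc(-c3ccccc3-c3nnn(CC(=O)O)n3)cc2)C1=O` has not yet been measured. It differs from compound 1 as follows: 2-(carboxymethyl)-2H-tetrazol-5-yl in place of carboxy on an aromatic carbon. Among the compounds with values here, the single step that bears on this change, a 1.3-fold higher number from compound 1 to compound 2 (0.12 log units; within the scatter), shows that exchanging the carboxy for a different group left the number essentially where it was, so no step beyond the scatter is expected here either. Compound 3 is therefore expected to give about 4 uM in this assay, within a range of 1.5 uM to 12 uM, an expected step of a 1.3-fold higher number from compound 1 to compound 3 (0.12 log units; within the scatter).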

Compound 3, concentration for half-maximal effect: 0.2 uM
For compound 3 the middle estimate is 20-fold (1.30 log units) above the measured one; the whole stated range lies above it.
By their numbers in this assay, from the lowest: compound 3; then compounds 1 and 2 (each within the scatter of the next).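

The group on this aromatic carbon can matter a great deal in this assay: with 2-(carboxymethyl)-2H-tetrazol-5-yl in place of carboxy, the number falls (a 15-fold lower number from compound 1 to compound 3 (1.18 log units; beyond the scatter)). The same group also gives a large step against (tert-butyl)sulfamoyl (a 20-fold lower number from compound 2 to compound 3 (1.30 log units; beyond the scatter)). The earlier pair therefore did not mean that this position is indifferent to its group, since two particular groups simply landed within the scatter of each other, and compound 3 now lies beyond the scatter of both.

Nothing available here accounts for the size of this change. The compounds shown also leave open whether the ring or its chain carries the effect, which a plain tetrazole without the carboxymethyl chain, a longer chain ending in a carboxylic acid, or the methyl ester of compound 3 could help to separate.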